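The source may hold more compounds than are shown below. What is called first, only, known or untested is meant among the compounds shown, and "the series" means these compounds.

Notes on the series, step from compound 2 to compound 4.

Three compounds sharing the same core have been run in a functional assay on HeLa cells (Homo sapiens) for antiproliferative activity, read by MTT assay, with a stated time of 72 h; on this read-out higher numbers stand for weaker inhibition and lower numbers for stronger inhibition. Compound 1 `O=C1O[C@H]([C@@H](O)Cn2cc(-c3cc(C(F)(F)F)cc(C(F)(F)F)c3)nn2)C(OCc2ccccc2)=C1OCc1ccccc1` gives 35500 nM. Compound 2 `CCCCCc1ccc(-c2cn(C[C@H](O)[C@H]3OC(=O)C(OCc4ccccc4)=C3OCc3ccccc3)nn2)cc1` gives 8390 nM, the lowest of the two numbers recorded; the gap to compound 1 is beyond the scatter, so compound 2 is the stronger inhibitor of the two. Compound 3 `O=C1O/C(=C\Cn2cc(-c3cc(C(F)(F)F)cc(C(F)(F)F)c3)nn2)C(OCc2ccccc2)=C1OCc1ccccc1` returns only a limit, > 100000 nM, and is not a number. That limit is the one named in the limit of > 100000 nM in this assay, at which 1 of the 3 values shown sits.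

Compound 4 `Cc1ccc(S(=O)(=O)NCc2cn(C[C@H](O)[C@H]3OC(=O)C(OCc4ccccc4)=C3OCc3ccccc3)nn2)cc1` is not yet measured. It differs from compound 2 in one place: (((4-methylphenyl)sulfonyl)amino)methyl in place of 4-pentylphenyl on an aromatic carbon.

For the measured compounds named here, no measured pair of compounds differs in a single place, so there is no measured step to lean on. Of the two numbers shown, the one from compound 2, 8390 nM, sits with the 4-pentylphenyl group, and the higher one from compound 1 sits with a different aromatic substituent; the change to compound 4 is of another kind again. A step toward weaker inhibition is expected, beyond the scatter but not as far as the limit. Compound 4 is estimated at 30000 nM, with a range of 8000 nM to 100000 nM, meaning an expected step of a 3.6-fold higher number from compound 2 to compound 4 (0.55 log units; beyond the scatter).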

Compound 4, half-maximal inhibitory concentration: 14400 nM
Compound 4: middle estimate off by 2.1-fold (0.32 log units), on the high side, and the stated range covers the measured number.
By their numbers in this assay, from the lowest: compounds 2 and 4 (each within the scatter of the next); then compound 1. At a limit, above all of these: compound 3.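

In this assay, the series now has its first step that can be read at a single place, on an aromatic carbon of the five-membered aromatic ring with 3 nitrogen: a 1.7-fold higher number from compound 2 to compound 4 (0.23 log units; within the scatter) is what the exchange of 4-pentylphenyl for (((4-methylphenyl)sulfonyl)amino)methyl gives. The two groups are therefore not separated at this position, although one is all carbon with no hydrogen-bond donors or acceptors and the other brings in nitrogen, oxygen, sulfur, a hydrogen-bond donor and hydrogen-bond acceptors, and both carry a six-membered aromatic ring of carbon only. Nothing in the data at hand bears on the reason for this result.

As far as these compounds go, it remains open whether the six-membered aromatic ring is needed at this carbon, which a simple amine or a plain alkyl chain there would test. From the compounds shown here alone, it is equally open whether the hydrogen on the sulfonamide nitrogen matters, which a methyl group in its place would show, and whether a carboxylic acid at this carbon would read alongside these two groups.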